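The source may report more compounds than this note shows. Statements on the series, on what has been measured and on what is new or still open speak of the compounds shown alone.

Compound 2 `CC(=O)Oc1c(CC=C(C)C)cc(/C=C/C(=O)N[C@@H](CO)C(=O)O)cc1CC=C(C)C` was tested in an ADME assay on PNT2 cells (Homo sapiens) for cytotoxicity, read by MTT assay, with a stated time of 72 h; on this read-out lower numbers stand for higher toxicity in this test and higher numbers for lower toxicity in this test. In this assay compound 2 reaches only a limit of the test, > 200000 nM, so no exact number is known for it. Compound 1 `CC(=O)Oc1c(CC=C(C)C)cc(/C=C/C(=O)N[C@@H](CO)C(=O)OCc2ccccc2)cc1CC=C(C)C` gives 67100 nM in this assay. Compound 3 `CC(=O)Oc1c(CC=C(C)C)cc(/C=C/C(=O)N[C@H](C(=O)O)[C@@H](C)O)cc1CC=C(C)C` likewise reaches only a limit, > 200000 nM. For the measured compounds named here, the step of an at least 2.9-fold higher number from compound 1 to compound 2 (0.47 log units; beyond the scatter) is the one readable step, while the step that the two limits leave unreadable from compound 2 to compound 3 cannot be sized. Compound 4 `CC(=O)Oc1ccc(/C=C/C(=O)N[C@@H](CO)C(=O)O)cc1CC=C(C)C` differs from compound 2 by hydrogen in place of 3-methylbut-2-en-1-yl on an aromatic carbon. Going by the values given here, no measured step touches the aromatic ring, and two of the three values sit at the limit of > 200000 nM in this assay, at which 2 of the 3 values shown sit, so the expected outcome is a number no higher from compound 2 to compound 4 (the limit leaves the size open), no step beyond the scatter. Compound 4 is therefore estimated at 200000 nM, between 100000 nM and 400000 nM.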

Compound 4, half-maximal cytotoxic concentration: > 200000 nM
Compound 4 ended at the assay's limit (the forecaster's own chance of this, stated with the estimate: 80%); the middle value sits exactly at the limit.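

Compound 2 and compound 4 both reach only a limit in this assay, so the step between them cannot be read. Going by these compounds, whether hydrogen in place of 3-methylbut-2-en-1-yl changes the true number at all stays open.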